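Methyl on the sulfonyl phenyl: two fluorophenyl cores

The source may hold more compounds than are shown below. What is called first, only, known or untested is meant among the compounds shown, and "the series" means these compounds.

Measured compounds in an ADME assay on L02 cells (Homo sapiens) for cytotoxicity, read by MTT assay, with a stated time of 24 h; on this read-out higher numbers stand for weaker inhibition and lower numbers for stronger inhibition:
compound 1 `O=C1/C(=C/c2cccc(F)c2)CN(S(=O)(=O)c2ccccc2)C/C1=C\c1cccc(F)c1` gives 16200 nM
compound 2 `Cc1ccc(S(=O)(=O)N2C/C(=C\c3cccc(F)c3)C(=O)/C(=C/c3cccc(F)c3)C2)cc1` gives 15700 nM
compound 3 `O=C1/C(=C/c2ccc(F)cc2)CN(S(=O)(=O)c2ccccc2)C/C1=C\c1ccc(F)cc1` gives 18800 nM

Compound 1 and compound 3 carry the same atoms joined differently; the difference between the two cores is not broken down here. Their values in this assay, compound 1 at 16200 nM and compound 3 at 18800 nM, lie within the usual scatter of each other, so nothing is read from that gap.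

The change from compound 1 to compound 2 is methyl in place of hydrogen on an aromatic carbon, and it made the step of a 1.0-fold lower number from compound 1 to compound 2 (0.01 log units; within the scatter).

Compound 4 `Cc1ccc(S(=O)(=O)N2C/C(=C\c3ccc(F)cc3)C(=O)/C(=C/c3ccc(F)cc3)C2)cc1` is not yet measured. It relates to compound 3 by methyl in place of hydrogen on an aromatic carbon, the same change, at the same place, on the core of compound 3 rather than that of compound 1. Since compound 3 sits at 18800 nM and the same change made the step of a 1.0-fold lower number from compound 1 to compound 2 (0.01 log units; within the scatter), the step is expected to be about a 1.0-fold lower number from compound 3 to compound 4 (0.01 log units; within the scatter). Compound 4 is therefore estimated at 18500 nM in this assay, with a range from 9000 nM to 37000 nM.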

Compound 4, half-maximal inhibitory concentration: 14000 nM
For compound 4 the middle estimate is 1.3-fold (0.12 log units) above the measured one, within the range that was stated.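

In this assay, methyl in place of hydrogen on the phenylsulfonyl group gives a 1.3-fold lower number from compound 3 to compound 4 (0.13 log units; within the scatter), so on the core of compound 3 the step is no larger than the scatter. Set beside the step on the core of compound 1, the change shows no readable difference between the two cores: the same change on two cores in this assay, a 1.0-fold lower number (0.01 log units; within the scatter) from compound 1 to compound 2 and a 1.3-fold lower number (0.13 log units; within the scatter) from compound 3 to compound 4, 1.3-fold (0.11 log units) apart, within the scatter of two such steps. Going by these compounds alone, this shows only that on both cores the methyl leaves the cytotoxicity read-out within the scatter; it does not show that a step of real size would carry from one core to another, since neither step here is beyond the scatter, and it says nothing about cores outside these two.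

The compounds shown leave open whether another group in the same place, such as a methoxy, an amine or a carboxylic acid, would give a step beyond the scatter. They also leave open whether the methyl step holds on a core carrying chloro or nitrile in place of the fluoro groups.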